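The compounds below may be only part of what the source reports. "The series", "measured", "known", "first", "only" and "open" are said of these compounds alone.

For the measured compounds named here, compound 1, `CN(C)CCCNc1c(C(=O)NCc2ccc(F)cc2)nc(Br)c2cccnc12`, is the only member of this small set that comes with a number. In a functional assay on MCF7 cells (Homo sapiens) for cytotoxicity, read by MTT assay, with a stated time of 72 h (on this read-out lower numbers stand for stronger inhibition and higher numbers for weaker inhibition), compound 1 gives 7000 nM, so it is the single point of reference here. Compound 2, `COc1ccc(CNC(=O)c2nc(Br)c3cccnc3c2N[C@H]2CC[C@H](N)CC2)cc1`, belongs to the same series, but for compound 2 the entry in this assay reads "not determined" (no result reported), and it therefore adds nothing to compare against.

Compound 3, `NCCCCCCNc1c(C(=O)NCc2ccc(F)cc2)nc(Br)c2cccnc12`, has not yet been tested. It differs from compound 1 in one place: 3-aminopropyl in place of dimethylamino on a saturated chain carbon, three bonds along the chain from a nitrogen on an aromatic ring. The rest of the molecule is unchanged, so any difference in the read-out would have to come from the end of that saturated chain. Going by the values given here, no measured pair in this set shows what such a swap does, so the expectation rests on compound 1 alone.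

The step expected from compound 1 to compound 3 is no change at the digits printed from compound 1 to compound 3 (within the scatter), which is estimated to stay within the usual scatter rather than move clearly in either direction. Compound 3 is thus expected to give about 7000 nM in this assay. The estimate for compound 3 runs from 2500 nM to 20000 nM.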

Compound 3, half-maximal inhibitory concentration: 2000 nM
Beside the measured number, compound 3's estimate is 3.5-fold (0.54 log units) above it; measured number outside the range, below it.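

The end of the saturated chain turns out to be a place where the read-out responds: in this assay the swap gives a 3.5-fold lower number from compound 1 to compound 3 (0.54 log units; beyond the scatter), a modest step but one beyond the usual scatter, and in the direction of stronger inhibition. A single number could not show this, and the pair now shows that the rest of the molecule can stay fixed while this one region shifts the result. No measurement at hand explains why the number falls.

Cut one bond further out, the same change reads 3-(dimethylamino)propyl to 6-aminohexyl, so the length of the chain and the kind of amine at its end change together, and this one step cannot separate the two. A plain amine on the shorter chain of compound 1, or a dimethylamino group on the longer chain of compound 3, would pull those two changes apart, while a carboxylic acid at the chain end would ask whether an amine is needed there at all.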